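Methyl for cyano: lipophilicity note on compound 4

A few compounds are considered here, and "the series" means these few. Any claim that something is new, unique, unknown or untested is made for them only; others in the source may bear on it.

Three compounds have numbers in a physicochemical assay for lipophilicity, using the shake flask method; a lower number here means a more polar compound, a higher number a more lipophilic compound. Compound 1 `C[C@H](Oc1ccc(/C=C/C(=O)O)cc1)c1c(Cl)ccc(F)c1Cl` gives 2.8, compound 2 `C[C@H](Oc1ccc2ncc(/C=C/C(=O)O)c(C#N)c2c1)c1c(Cl)ccc(F)c1Cl` gives 2.3 and compound 3 `C[C@H](Oc1ccc2c(c1)c(C1CC1)c(/C=C/C(=O)O)c[n+]2[O-])c1c(Cl)ccc(F)c1Cl` gives 1.7. Compound 2 thus stands second highest of the three, with compound 1 higher by a step beyond the scatter and compound 3 lower, also beyond the scatter. Compound 4 `Cc1c(/C=C/C(=O)O)cnc2ccc(O[C@@H](C)c3c(Cl)ccc(F)c3Cl)cc12` is not yet measured; it differs from compound 2 in one place: methyl in place of cyano on an aromatic carbon. Within the data shown here, no measured pair shows this change, so its size rests on the change itself. A moderate rise in this assay is expected, beyond the scatter: the group that leaves carries one hydrogen-bond acceptor, the one that enters none. Compound 4 is therefore estimated at 2.9, between 2.5 and 3.3. The expected step is a number 0.60 log units higher from compound 2 to compound 4 (beyond the scatter).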

Compound 4, distribution coefficient: 3
For compound 4 the middle estimate is 0.10 log units below the measured one; the range from low to high includes it.
By their numbers in this assay, from the lowest: compound 3; then compound 2; then compounds 1 and 4 (each within the scatter of the next).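

In this assay the aromatic carbon ortho to the 2-carboxyethenyl group now has its first comparison in one place: methyl in place of cyano gives a number 0.70 log units higher from compound 2 to compound 4 (beyond the scatter) and so a modest step. Among these compounds, the earlier compounds offered no such pair, so this is the only sized change so far. Nothing available bears on the origin of this step. As far as these compounds go, whether other groups at this position, such as ethyl, methoxy or an amine, would fall near methyl or cyano remains open. So does whether the same change gives a similar step on the core of compound 3.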